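A few compounds are considered here, and "the series" means these few. Any claim that something is new, unique, unknown or untested is made for them only; others in the source may bear on it.

Series notes. For the measured compounds named here, compound 1 `Oc1cccc(-c2cc(-c3cccc(Cl)c3)nc(-c3ccccn3)c2)c1` in an ADME assay on HEK293 cells (Homo sapiens) for cytotoxicity, read by CCK-8 assay and cell counting, with a stated time of 2 days (on this read-out lower numbers stand for stronger inhibition and higher numbers for weaker inhibition), is recorded as "not determined" (no result reported), and compound 3 `Oc1cccc(-c2cc(-c3ccccn3)nc(-c3ccccc3Cl)c2)c1` is likewise recorded as "not determined" (no result reported), so no step on that read-out can be set against compound 1. Going by the values given here, the only number in the set comes from compound 2 `Oc1cccc(-c2cc(-c3ccc(Cl)cc3)nc(-c3ccccn3)c2)c1`, which in this assay gives 14000 nM. Compound 4 `Oc1cccc(-c2cc(-c3ccccc3)nc(-c3cccc(Cl)c3)c2)c1` differs from compound 1 in one place: phenyl in place of pyridin-2-yl on an aromatic carbon. Among the compounds with values here, no measured pair covers this exchange, and compound 1 itself gives no number to step from. The expectation is no shift beyond the usual scatter of this assay in either direction, taking the value of compound 2, 14000 nM, as the only anchor. Compound 4 is therefore estimated at 15000 nM, with a range from 5000 nM to 50000 nM.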

Compound 4, half-maximal inhibitory concentration: 3120 nM
Estimate against measurement, compound 4: 4.8-fold (0.68 log units) above; measured number outside the range, below it.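

In this assay no step can be read between compound 1 and compound 4. The compounds shown leave open what phenyl in place of pyridin-2-yl does to this read-out. No evidence bearing on the result is at hand.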